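Swapping a nitro for a hydroxy on a chalcone

This account rests on a few compounds, and the source may have more. Where it says the series, first, only, none or still open, it means among the compounds named here.

Of the compounds shown here, three have been tested in a functional assay on MCF7 cells (Homo sapiens) for cytotoxicity, read by MTT assay, with a stated time of 68 h; on this read-out higher numbers stand for weaker inhibition and lower numbers for stronger inhibition. Compound 1 `O=C(/C=C/c1cccc(OCc2ccccc2)c1)c1ccc(Cl)cc1Cl` gives 9400 nM. Compound 2 `O=C(/C=C/c1cccc(OCc2ccccc2)c1)c1ccc([N+](=O)[O-])cc1` gives 17500 nM. Compound 3 `COc1cc(C2Oc3cc(/C=C/C(=O)c4ccccc4O)ccc3OC2CO)ccc1O`, built on a different core, gives 12100 nM. The number for compound 2 sits within the usual scatter of both compound 3 and compound 1, so on the evidence so far the three cannot be told apart.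

Compound 4 `O=C(/C=C/c1cccc(OCc2ccccc2)c1)c1ccc(O)cc1` shares its core with compound 2 and differs in one place: hydroxy in place of nitro on an aromatic carbon. Among the measured compounds shown here, the only measured step on this core, a 1.9-fold higher number from compound 1 to compound 2 (0.27 log units; within the scatter), exchanged one para-substituted ring for another and stayed within the scatter. For the measured compounds named here, no measured pair shows a nitro giving way to a hydroxy, so there is nothing that points to a shift in either direction. The reasonable expectation in this assay is therefore no step beyond the scatter, and the step from compound 2 to compound 4 is estimated at a 1.2-fold lower number from compound 2 to compound 4 (0.07 log units; within the scatter).

For compound 4 the expected value in this assay is 15000 nM, with a range from 5000 nM to 45000 nM.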

Compound 4, half-maximal inhibitory concentration: 2800 nM
The estimate for compound 4 lay 5.4-fold (0.73 log units) above the measured number; the measured number lies below the stated range.
By their numbers in this assay, from the lowest: compound 4; then compounds 1, 3 and 2 (each within the scatter of the next).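

In this assay, the group on this aromatic carbon can matter: a 6.3-fold lower number from compound 2 to compound 4 (0.80 log units; beyond the scatter) is beyond the scatter, whereas the earlier ring exchange on the same core, a 1.9-fold higher number from compound 1 to compound 2 (0.27 log units; within the scatter), stayed within it. The hydroxy compound also separates from the dichlorinated one, with a 3.4-fold lower number from compound 1 to compound 4 (0.53 log units; beyond the scatter) also beyond the scatter, so compound 4 stands apart from both compound 1 and compound 2, which could not be told apart from each other. Nothing measured here accounts for this drop, so the step from nitro to hydroxy stands as an observation without an explanation.

The compounds shown leave open whether the lower number is specific to hydroxy or would also appear with other small groups on this carbon, such as an amine or a fluorine atom. A methoxy group in the same place would show whether the result depends on the hydrogen of the hydroxy or whether the oxygen alone is enough, and a carboxylic acid would test a larger oxygen-bearing group there.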